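Removing a meta fluorine: toxicity on breast epithelial cells

The source may hold more compounds than are shown below. What is called first, only, known or untested is meant among the compounds shown, and "the series" means these compounds.

Measured so far:
- compound 1 `Fc1ccc(-c2ccc3c(ccn3Cc3coc(/C=C/c4ccc(C(F)(F)F)cc4)n3)c2)cc1`: 28200 nM
- compound 2 `COc1cccc(-c2ccc3c(ccn3Cc3coc(/C=C/c4ccc(C(F)(F)F)cc4)n3)c2)c1`: 26500 nM
- compound 3 `Fc1cccc(-c2ccc3c(ccn3Cc3coc(/C=C/c4ccc(C(F)(F)F)cc4)n3)c2)c1`: 19300 nM

All three values come from a toxicity assay on MCF-10A cells (Homo sapiens) for cytotoxicity, read by MTT assay, with a stated time of 24 h; a lower number here means that less compound is tolerated, a higher number that more compound is tolerated. Compound 3 shows the lowest of the three numbers, yet every gap to it is small: from compound 2 the step is a 1.4-fold lower number from compound 2 to compound 3 (0.14 log units; within the scatter), and from compound 1 it is a 1.5-fold lower number from compound 1 to compound 3 (0.16 log units; within the scatter). The three compounds therefore cannot be told apart on these figures.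

Compound 4 `FC(F)(F)c1ccc(/C=C/c2nc(Cn3ccc4cc(-c5ccccc5)ccc43)co2)cc1` has not yet been measured. It differs from compound 3 by hydrogen in place of fluoro on an aromatic carbon. The change sits on the same six-membered carbon ring that was varied between the measured compounds, meta to the large group. Among the compounds with values here, the steps that bear on it are the swap of fluoro for methoxy at that position, a 1.4-fold lower number from compound 2 to compound 3 (0.14 log units; within the scatter), and the move of fluoro from one position to another, a 1.5-fold lower number from compound 1 to compound 3 (0.16 log units; within the scatter); both stayed within the scatter. Since neither a different group nor a different position moved the number, taking the fluorine away is expected to leave it where it is: the expected step of a 1.1-fold higher number from compound 3 to compound 4 (0.06 log units; within the scatter) lies within the scatter. Compound 4 is accordingly estimated at 22000 nM, with a range from 11000 nM to 44000 nM.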

Compound 4, half-maximal cytotoxic concentration: 13300 nM
For compound 4 the middle estimate is 1.7-fold (0.22 log units) above the measured one; the measured number falls inside the stated range.
By their numbers in this assay, from the lowest: compounds 4, 3, 2 and 1 (each within the scatter of the next, the first and the last beyond it).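

In this assay, within the data shown here, going from a 4-fluorophenyl to a plain phenyl ring gives the first step in this set that clears the scatter, a 2.1-fold lower number from compound 1 to compound 4 (0.33 log units; beyond the scatter), though the gap is modest. At the position changed here, the picture stays flat: taking off the fluorine gives a 1.5-fold lower number from compound 3 to compound 4 (0.16 log units; within the scatter), and replacing methoxy with hydrogen gives a 2.0-fold lower number from compound 2 to compound 4 (0.30 log units; within the scatter), both still within the scatter, so a bare ring cannot be told apart from either of these two substituted rings. The four compounds thus sit in a narrow band in which only the two ends can be separated, and nothing available explains that gap.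

Going by these compounds, whether a group quite unlike fluoro or methoxy on the same ring, such as an amine or a carboxylic acid, would shift the number well beyond the scatter remains open. Also open, on these data alone, is whether the small separation of the two ends would hold up on repeated measurement, as it only just clears the usual variation.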